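Swapping the aryl group on the aniline nitrogen

The compounds below may be only part of what the source reports. "The series", "measured", "known", "first", "only" and "open" are said of these compounds alone.

Compound 1 `CCc1ccc(Nc2ncnc3cc(OC)c(OCCCCC(=O)Nc4ccc(S(N)(=O)=O)cc4)cc23)cc1` gives 12100 nM in a functional assay on A549 cells (Homo sapiens) for antiproliferative activity, read by MTT assay, with a stated time of 72 h; on this read-out lower numbers stand for stronger inhibition and higher numbers for weaker inhibition.
Compound 2 `COc1cc2ncnc(Nc3ccccc3)c2cc1OCCCCC(=O)Nc1ccc(S(N)(=O)=O)cc1` reaches only the assay limit, > 40000 nM, which is a limit and not a number.
Compound 3 `NS(=O)(=O)c1ccc(NC(=S)Nc2ccc3ncnc(Nc4cccc(C(F)(F)F)c4)c3c2)cc1` gives 10100 nM.

Among the two numbers that are not limits, compound 3 has the lower one, but its gap to compound 1 lies within the usual scatter, so the two cannot be ordered. Among the compounds with values here, the one measured step, an at least 3.3-fold higher number from compound 1 to compound 2 (0.51 log units; beyond the scatter), shows that taking away the ethyl group weakens inhibition enough to push the value to the limit of > 40000 nM in this assay, at which 1 of the 3 values shown sits.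

Compound 4 `Cc1ccc(Nc2ncnc3ccc(NC(=S)Nc4ccc(S(N)(=O)=O)cc4)cc23)cc1` differs from compound 3 by 4-methylphenyl in place of 3-(trifluoromethyl)phenyl on a nitrogen on an aromatic ring. Within the data shown here, no measured step covers a swap of this kind: the step from compound 1 to compound 2 removes a group rather than exchanging one for another, and it sits on a different shared core. The only hint is that an alkyl group on that ring helped compound 1, and compound 4 keeps a methyl there.

Given the lack of a direct precedent, a modest change is expected, with the estimate for compound 4 placed at 15000 nM, within 5000 nM to 45000 nM, corresponding to an expected step of a 1.5-fold higher number from compound 3 to compound 4 (0.17 log units; within the scatter).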

Compound 4, half-maximal inhibitory concentration: 2840 nM
Beside the measured number, compound 4's estimate is 5.3-fold (0.72 log units) above it; measured number outside the range, below it.
By their numbers in this assay, from the lowest: compound 4; then compounds 3 and 1 (each within the scatter of the next). At a limit, above all of these: compound 2.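

Within the data shown here, compound 3 and compound 4 give the first measured exchange of one aryl group for another on this nitrogen, since the earlier step only removed an ethyl group on the core of compound 1. In this assay, among these compounds, 4-methylphenyl in place of 3-(trifluoromethyl)phenyl gives a 3.6-fold lower number from compound 3 to compound 4 (0.55 log units; beyond the scatter) and is the only change between the two structures, so the aryl group on this nitrogen clearly affects antiproliferative activity on this second core as well. The exchange alters both the group on the ring and its place there, and nothing measured here explains the step or separates those two changes.

On these data alone, it remains open whether the lower number follows from having a methyl group, from where that group sits on the ring, or simply from losing the trifluoromethyl group. As far as these compounds go, how other groups on that ring, such as a chlorine, a methoxy group or an amine, would compare on this core also remains open, as does whether the same exchange would give a similar step on the core of compound 1.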